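The compounds below may be only part of what the source reports. "The series", "measured", "known", "first", "only" and "open" are said of these compounds alone.

Working notes on the series.

The series is built on the shared core of compound 1, `COc1cccc(S(=O)(=O)/C=C/c2ccccn2)c1`. In an ADME assay on BV-2 cells (Mus musculus) for cytotoxicity, with a stated time of 24 h, tested at 10 uM (on this read-out higher numbers stand for a weaker effect at the one concentration tested and lower numbers for a stronger effect), compound 1 gives 100%. Compound 2, `COc1cccc(S(=O)(=O)/C=C/c2ncccc2F)c1`, carries fluoro in place of hydrogen on an aromatic carbon, and in this assay compound 2 gives 100%. Going by the values given here, the single measured step, no change at the digits printed from compound 1 to compound 2 (within the scatter), shows that this substitution leaves the read-out where it was. Compound 2 therefore stands level with compound 1 at the digits recorded, with no difference beyond the scatter between the two.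

The next compound, compound 3, `COc1cccc(S(=O)(=O)/C=C/c2ncccc2Cl)c1`, differs from compound 2 as follows:
chloro in place of fluoro on an aromatic carbon

Among the compounds with values here, the only step that bears on this exchange is the one from compound 1 to compound 2, in which adding a halogen on the same aromatic carbon produced no change beyond the scatter. Exchanging one halogen for another at that carbon is accordingly expected to give no step beyond the scatter in this assay, so the estimated step for compound 3 is no change at the digits printed from compound 2 to compound 3 (within the scatter). Compound 3 is expected to give 100%, within a range from 87% to 108%.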

Compound 3, a percentage reported as activity, at one concentration (the size of the read-out at that concentration, not a potency): 100%
Compound 3: the middle estimate sits on the measured number at the digits printed, and the stated range covers the measured number.
By their numbers in this assay, from the lowest: compounds 1, 2 and 3 (each within the scatter of the next).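

Compound 3 shows that the identity of the halogen on this aromatic carbon, two atoms from the ring nitrogen, does not separate the compounds at this level: in this assay chloro in place of fluoro gives no change at the digits printed from compound 2 to compound 3 (within the scatter) and the read-out stays in place. Set against the parent, chloro in place of hydrogen gives no change at the digits printed from compound 1 to compound 3 (within the scatter) and thus extends to a second halogen what the fluoro compound alone had shown for this carbon. No supporting information is available on what lies behind this flat result.

From the compounds shown here alone, whether an amine, a carboxylic acid or a longer chain on this same carbon would also leave the read-out of this assay in place remains open, as does the outcome of chloro or fluoro on the other carbons of this ring. With all three compounds read at one concentration, the series also leaves open whether they would stay level at any other concentration.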